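Swapping a methoxy for a chloro on the acid ring

The source may hold more compounds than are shown below. What is called first, only, known or untested is meant among the compounds shown, and "the series" means these compounds.

This piece follows a single change in a series of compounds tested in an assay on HEK293 cells for positive allosteric modulation of metabotropic glutamate receptor 2 (Rattus norvegicus), read by thallium flux, with a stated time of 2.5 min; on this read-out higher numbers stand for larger maximal responses and lower numbers for smaller maximal responses. Compound 2, `COc1cc(C(=O)O)ccc1OCCCCOc1ccc(C(=O)CC(C)C)c(O)c1C`, gives 85.7% in this assay and stands highest of the three measured numbers. Compound 1, `COc1cc(C(=O)O)ccc1OCCCCOc1ccc(C(=O)C(C)C)c(O)c1C`, gives 73.1%, and compound 3, `Cc1c(OCCCCOc2ccc(C(=O)O)cc2)ccc(C(=O)CC2CCCC2)c1C`, gives 16.2%, far beneath the other two. Among the measured compounds shown here, the one measured step that changes a single place is a number 12.6 percentage points higher from compound 1 to compound 2 (beyond the scatter).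

Compound 4, `Cc1c(OCCCCOc2ccc(C(=O)O)cc2Cl)ccc(C(=O)CC(C)C)c1O`, differs from compound 2 in one place: chloro in place of methoxy on an aromatic carbon. The place is on an aromatic carbon of a six-membered aromatic ring of carbon only, ortho to a large group and meta to a carboxy group.

For the measured compounds named here, no measured step touches this part of the molecule; compound 3 lacks the methoxy but differs from compound 2 in more than one place, so its low number cannot be laid to the methoxy alone. The step from compound 1 to compound 2 concerns the carbonyl side and gives no direction here. With no guide, a modest loss is expected for compound 4, a number 17.7 percentage points lower from compound 2 to compound 4 (beyond the scatter), with wide uncertainty. Compound 4 is therefore estimated at 68%, within a range from 35% to 100%.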

Compound 4, largest response reached (reported as percent of maximum), in percent of the reference or control that the assay uses: 99.5%
Compound 4: the middle estimate sits 31.5 percentage points below what was measured, and the stated range covers the measured number.
By their numbers in this assay, from the lowest: compound 3; then compound 1; then compound 2; then compound 4.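

Among the compounds shown here, this is the first measured step at this position, ortho to a large group and meta to a carboxy group, and in this assay chloro in place of methoxy gives a number 13.8 percentage points higher from compound 2 to compound 4 (beyond the scatter) on this scale. A large maximal response here therefore does not depend on the methoxy: chloro, with one heavy atom against two and no hydrogen-bond acceptor against one, serves at least as well in this pair. Nothing available explains why the number moves in this direction.

From the compounds shown here alone, whether fluoro, bromo or a methyl group on this carbon would match chloro remains open. It is also unknown whether the same swap would give a similar step with the isopropyl group of compound 1 on the carbonyl carbon.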